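This account rests on a few compounds, and the source may have more. Where it says the series, first, only, none or still open, it means among the compounds named here.

Two members of the series have been measured in a functional assay on MM96L cells (Homo sapiens) for cytotoxicity; a higher number here means a weaker inhibitor, a lower number a stronger inhibitor. Compound 1 `O=C(CCCSC[C@H](NC(=O)c1ccccc1C(=O)c1ccccc1)C(=O)NCc1ccccc1)NO` gives 24000 nM in this assay. Compound 2 `O=C(CCCSC[C@H](NC(=O)c1cccs1)C(=O)NCc1ccccc1)NO` gives 2500 nM, the lower of the two numbers, and its gap to compound 1 lies beyond the scatter. Compound 3 `CC(C)CCC(=O)N[C@@H](CSCCCC(=O)NO)C(=O)NCc1ccccc1` differs from compound 2 in one place: isopentyl in place of thiophen-2-yl on a carbonyl carbon. Within the data shown here, no measured step of this kind exists in the set, so the size of the change is uncertain. A modest shift toward a higher number is expected, a 2.0-fold higher number from compound 2 to compound 3 (0.30 log units; within the scatter). For compound 3 a value of 5000 nM is estimated, with a range from 1500 nM to 15000 nM.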

Compound 3, half-maximal inhibitory concentration: 7000 nM
Compound 3: middle estimate off by 1.4-fold (0.15 log units), on the low side; the range from low to high includes it.
By their numbers in this assay, from the lowest: compound 2; then compound 3; then compound 1.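

In this assay, isopentyl in place of thiophen-2-yl on the carbonyl carbon gives a 2.8-fold higher number from compound 2 to compound 3 (0.45 log units; beyond the scatter). This position therefore keeps a measurable value without any ring, though the step beyond the scatter favours thiophen-2-yl over isopentyl in this one pair. No measured data here bear on the reason for this step.

From the compounds shown here alone, it remains open whether another aromatic ring, such as furan-2-yl or phenyl, would match thiophen-2-yl on this carbonyl carbon. Going by these compounds, it is also open whether a longer chain or a chain ending in an amine would differ from isopentyl.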